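The source may hold more compounds than are shown below. What is called first, only, known or untested is meant among the compounds shown, and "the series" means these compounds.

Measured compounds:
compound 1 `CCc1nc2cc(Cl)ccn2c1C(=O)NCc1ccc2c(c1)CCN(Cc1cc(F)cc(F)c1)C2` — 48 ug/mL
compound 2 `CCc1nc2ccc(Cl)cn2c1C(=O)NCc1ccc2c(c1)CCN(Cc1ccc(C(F)(F)F)cn1)C2` — > 64 ug/mL
compound 3 `CCc1nc2ccc(Cl)cn2c1C(=O)NCc1ccc2c(c1)CCN(Cc1ccc(C(F)(F)F)cc1)C2` — > 64 ug/mL

Among the compounds with values here, in an ADME assay on Vero cells (Chlorocebus sabaeus) for cytotoxicity, read by MTT assay, with a stated time of 72 h (on this read-out lower numbers stand for higher toxicity in this test and higher numbers for lower toxicity in this test), compound 1 gives 48 ug/mL, and this is the only actual number among the three measured compounds. In this assay compound 2 gives > 64 ug/mL, which is a limit of the assay rather than a number. In this assay compound 3 likewise gives > 64 ug/mL, again a limit. Within the data shown here, both of those values sit at the limit of > 64 ug/mL in this assay, at which 2 of the 3 values shown sit, so compound 1 stands apart simply as the one compound for which a number was read. Among the measured compounds shown here, the single step between measured compounds, a step that the two limits leave unreadable from compound 2 to compound 3, cannot be sized, since both ends are limits.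

Compound 4 `CCc1nc2cc(Cl)ccn2c1C(=O)NCc1ccc2c(c1)CCN(Cc1ccc([N+](=O)[O-])o1)C2` differs from compound 1 by 5-nitrofuran-2-yl in place of 3,5-difluorophenyl on a saturated chain carbon bound to an amine nitrogen in a ring. For the measured compounds named here, no measured step touches this change: the only step recorded involves a different pair of groups and is unreadable anyway. With nothing to point toward a shift, the expectation for compound 4 is a step of no more than the usual scatter, a 1.1-fold lower number from compound 1 to compound 4 (0.03 log units; within the scatter), and an estimated value of 45 ug/mL, with a range from 20 ug/mL to 100 ug/mL.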

Compound 4, half-maximal cytotoxic concentration: > 64 ug/mL
Compound 4 ended at the assay's limit; the forecaster's own chance of this, stated with the estimate: 30%; middle value at least 1.4-fold (0.15 log units) from the limit.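

In this assay compound 4 gives > 64 ug/mL, which is a limit of the assay and not a number. On a saturated chain carbon bound to an amine nitrogen in a ring, replacing 3,5-difluorophenyl with 5-nitrofuran-2-yl therefore gives an at least 1.3-fold higher number from compound 1 to compound 4 (0.12 log units; that floor lies within the scatter), so only a floor is known and the true size of the step is not. Unlike the earlier step with limits at both ends, this one has a number at one end, and it shows that a five-membered aromatic ring with 3 hydrogen-bond acceptors can stand here without the number falling, though the readings in this test offer little room to tell compounds apart: the limit of > 64 ug/mL in this assay, at which 3 of the 4 values shown sit.

The compounds shown leave open how far compound 4 really lies from compound 1, and whether the step belongs to the furan ring or to the nitro group, as the two enter together. A plain furan-2-yl or a 3-nitrophenyl at this place would separate those two parts, while an amine on the ring would show whether a quite different kind of group is also accepted.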